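The compounds below may be only part of what the source reports. "The series", "measured", "known", "first", "only" and "open" are said of these compounds alone.

Compounds measured so far:
compound 1, `C=C1[C@H](C)CCC[C@]1(C)CC/C(C)=C/CC1=C(O)C(=O)C=C(N[C@@H](C(=O)O)C(C)C)C1=O` — 6.2 ug/mL in an ADME assay on KB cells (Homo sapiens) for cytotoxicity, with a stated time of 48 h; on this read-out higher numbers stand for weaker inhibition and lower numbers for stronger inhibition
compound 2, `CC1=CCC[C@](C)(CC/C(C)=C/CC2=C(O)C(=O)C=C(NCC(=O)O)C2=O)[C@@H]1C` — 5.4 ug/mL
compound 3, `CC1=CCC[C@](C)(CC/C(C)=C/CC2=C(O)C(=O)C=C(N[C@@H](C(=O)O)[C@H](C)O)C2=O)[C@@H]1C` — > 10 ug/mL, a limit

Compound 1 holds the higher of the two numbers, with compound 2 within the scatter of it. Compound 3 sits at the limit of > 10 ug/mL in this assay, at which 1 of the 3 values shown sits. Going by the values given here, the one measured step, an at least 1.8-fold higher number from compound 2 to compound 3 (0.26 log units; that floor lies within the scatter), concerns a different place and does not bear on the change to compound 4, `CC1=CCC[C@](C)(CC/C(C)=C/CC2=C(O)C(=O)C=C(N[C@@H](C(=O)O)C(C)C)C2=O)[C@@H]1C`, which is a group of 9 heavy atoms (9 carbon; one six-membered non-aromatic ring of carbon only) in place of a group of 9 heavy atoms (9 carbon; one six-membered non-aromatic ring of carbon only), on a saturated chain carbon, two bonds along the chain from a double-bonded chain carbon. Among the compounds with values here, no measured pair isolates this change; compounds 1 and 2 differ at two places and give numbers within the scatter. Compound 4 is therefore expected to show no step beyond the scatter, a 1.0-fold lower number from compound 1 to compound 4 (0.01 log units; within the scatter). The estimated value of compound 4 is 6 ug/mL, within 3 ug/mL to 12 ug/mL.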

Compound 4, half-maximal inhibitory concentration: > 10 ug/mL
Compound 4: a limit, no number; the forecaster's own chance of this, stated with the estimate: 20%; middle value at least 1.6-fold (0.22 log units) from the limit.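

Compound 4 gives > 10 ug/mL in this assay, which is a limit and not a number: the limit of > 10 ug/mL in this assay, at which 2 of the 4 values shown sit. Going by these compounds alone, this is the first direct reading of the ring change at this position, and 1,2,3-trimethylcyclohex-3-en-1-yl gives an at least 1.6-fold higher number from compound 1 to compound 4 (0.20 log units; that floor lies within the scatter). On the saturated chain carbon bound to an amine nitrogen and a carbonyl carbon, isopropyl gives an at least 1.8-fold higher number from compound 2 to compound 4 (0.26 log units; that floor lies within the scatter), while the step involving compound 3 cannot be read.

Neither floor shows whether the true step exceeds the scatter. As far as these compounds go, how an amine or a longer chain in place of isopropyl on that carbon would read remains open.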